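Opening a Ring on a Weakly Active Core

The source may hold more compounds than are shown below. What is called first, only, known or untested is meant among the compounds shown, and "the series" means these compounds.

Compound 1 `COc1ccc(-c2c(-c3ccc(OC)cc3)n(Cc3ccccc3)c3ncn([C@@H]4CCCC[C@H]4O)c(=N)c23)cc1` carries a 2-hydroxycyclohexyl group on an aromatic nitrogen of its core. In a functional assay on PC-3M cells (Homo sapiens) for antiproliferative activity, read by microscopy, with a stated time of 24 h (a lower number here means a stronger inhibitor, a higher number a weaker inhibitor), compound 1 gives only a limit of the assay, > 20000 nM, so no single number is known for it; it stands at the edge of what the assay can report, as the limit of > 20000 nM in this assay, at which 1 of the 2 values shown sits, shows. A related compound, compound 2 `COc1ccc(Cn2c(-c3ccccc3)c(-c3ccccc3)c3c(=N)n(CC4CCCO4)cnc32)cc1`, is measured in this assay at 8630 nM; 8510 nM (2 entries), and its repeated entries, (the several entries of compound 2 in this assay, 8630 nM; 8510 nM (2 entries)), agree with one another.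

Compound 3 `COc1ccc(-c2c(-c3ccc(OC)cc3)n(Cc3ccccc3)c3ncn(CCCO)c(=N)c23)cc1` has not yet been measured. It differs from compound 1 in one place: 3-hydroxypropyl in place of 2-hydroxycyclohexyl on an aromatic nitrogen. Among the measured compounds shown here, no pair of measured compounds differs in a single place here, so no measured step exists to lean on. Because compound 1 sits at a limit, > 20000 nM, the step to compound 3 cannot be given a size from the data; a change no larger than the usual scatter, in either direction, seems as likely as a real shift.

Compound 3 is therefore expected to come out near 25000 nM, somewhere between 8000 nM and 80000 nM, which would mean an estimated step that the limit leaves unreadable from compound 1 to compound 3.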

Compound 3, half-maximal inhibitory concentration: > 20000 nM
Compound 3: a limit, no number; the forecaster's own chance of this, stated with the estimate: 60%; the middle value is on the limit's open side.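

In this assay compound 3 gives > 20000 nM, which is a limit of the assay and not a number. Compound 1 also sits at a limit, so the step between compound 1 and compound 3 cannot be read. The compounds shown leave open whether 3-hydroxypropyl in place of 2-hydroxycyclohexyl changes antiproliferative activity at all.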